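Non-aromatic five-membered ring in place of a heteroaromatic one

This account rests on a few compounds, and the source may have more. Where it says the series, first, only, none or still open, it means among the compounds named here.

Measured so far in an assay on CHO cells for displacement of a labelled ligand from prostaglandin E2 receptor EP3 subtype (Homo sapiens), read by radioligand binding; a lower number here means a stronger inhibitor, a higher number a weaker inhibitor:
- compound 1, `CC(C)C(c1cnc(N)s1)c1ccc(-c2ccc3cccc(F)c3c2)[nH]c1=O`: compound 1 gives 16 nM
- compound 2, `CC(C)C(c1noc(=O)[nH]1)c1ccc(-c2ccc3cccc(F)c3c2)[nH]c1=O`: compound 2 gives 15 nM

Among the compounds with values here, compound 2 holds the lowest of the two numbers, but its only neighbour is compound 1, and a 1.1-fold lower number from compound 1 to compound 2 (0.03 log units; within the scatter). The two values therefore stand at the same level; neither compound can be called stronger.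

Compound 3, `CC(C)C(/C=C1\CCNC1=O)c1ccc(-c2ccc3cccc(F)c3c2)[nH]c1=O`, carries the change (a group of 7 heavy atoms (5 carbon, 1 nitrogen, 1 oxygen; one five-membered non-aromatic ring with 1 hetero atom) in place of a group of 6 heavy atoms (2 carbon, 2 nitrogen, 2 oxygen; one five-membered aromatic ring with 3 hetero atoms), on a saturated chain carbon bound to an aromatic carbon and a saturated chain carbon). Within the data shown here, the only measured step that touches this position is the one from compound 1 to compound 2, an exchange of one five-membered aromatic ring with hetero atoms for another, and it left this assay unchanged. That step speaks for tolerance at the saturated chain carbon bound to an aromatic carbon and a saturated chain carbon, but it does not cover a non-aromatic ring with one hetero atom attached through a double bond outside the ring, which is a larger departure than anything measured. The expectation is a step of a 2.7-fold higher number from compound 2 to compound 3 (0.43 log units; beyond the scatter), toward a somewhat higher number, though a result within the scatter is plausible. Compound 3 is estimated at 40 nM, range 12 nM to 130 nM.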

Compound 3, inhibition constant: 2.2 nM
Compound 3: middle estimate off by 18-fold (1.26 log units), on the high side; measured number below the stated range.
By their numbers in this assay, from the lowest: compound 3; then compounds 2 and 1 (each within the scatter of the next).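

In this assay, within the data shown here, the group holding one five-membered non-aromatic ring with 1 hetero atom is the first change on the saturated chain carbon bound to an aromatic carbon and a saturated chain carbon to move the number beyond the scatter (a 6.8-fold lower number from compound 2 to compound 3 (0.83 log units; beyond the scatter); a 7.3-fold lower number from compound 1 to compound 3 (0.86 log units; beyond the scatter)). The position therefore does more than tolerate exchange between five-membered aromatic rings: no aromatic ring is needed in this group to hold the number, and the step is the same in direction from either aromatic compound, even though the entering group has 1 hydrogen-bond acceptor against 3 in the group of compound 2 and the donor count stays at 1. No measurement on hand gives a reason for the lower number.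

The compounds shown leave open which part of the new group carries the step, since the ring, its carbonyl, the amide hydrogen and the double bond outside the ring all enter together. A saturated chain in place of the double bond, an open-chain amide, a carboxylic acid or an amine at this carbon would separate these parts and show how far the number can be pushed.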